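A few compounds are considered here, and "the series" means these few. Any claim that something is new, unique, unknown or untested is made for them only; others in the source may bear on it.

Measured compounds in a functional assay on HepG2 cells (Homo sapiens) for inhibition, read by MTT assay, with a stated time of 72 h; a lower number here means a stronger inhibitor, a higher number a weaker inhibitor:
Compound 1 `CC(C)n1ncc2c(C(=O)NCc3cn(-c4ccccc4)nn3)cccc21` gives > 40000 nM, a limit of the assay.
Compound 2 `CC(C)n1ncc2c(C(=O)NCc3cn(-c4ccc(F)cc4)nn3)cccc21` gives > 40000 nM, likewise a limit.
Compound 3 `CC(C)n1ncc2c(C(=O)NCc3cn(-c4cccc(Br)c4)nn3)cccc21` gives > 40000 nM, likewise a limit.

Compound 1 stands only at a limit in this assay; all three values sit at the limit of > 40000 nM in this assay, at which 3 of the 3 values shown sit, so none of the compounds can be placed relative to another. Compound 4 `Cc1cccc(-n2cc(CNC(=O)c3cccc4c3cnn4C(C)C)nn2)c1` differs from compound 1 by methyl in place of hydrogen on an aromatic carbon. For the measured compounds named here, the steps that bear on this change are the other substitutions on the same ring, a step that the two limits leave unreadable from compound 1 to compound 2 and a step that the two limits leave unreadable from compound 1 to compound 3; neither has a readable size, and a step that the two limits leave unreadable from compound 2 to compound 3 adds nothing readable either. No readable step in either direction is therefore expected in this assay, and compound 4 is expected to remain at the limit. The estimate for compound 4 is 60000 nM (range 30000 nM to 200000 nM), an expected step that the limit leaves unreadable from compound 1 to compound 4.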

Compound 4, half-maximal inhibitory concentration: > 40000 nM
Compound 4: no number, only a limit; the forecaster's own chance of this, stated with the estimate: 90%; the middle value lies beyond the limit too.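

No step can be read among compound 1, compound 2, compound 3 and compound 4 in this assay, as each value is a limit: the limit of > 40000 nM in this assay, at which 4 of the 4 values shown sit.

Whether any phenyl substitution changes inhibition in this assay remains open, as does any ranking of these compounds.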